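A few compounds are considered here, and "the series" means these few. Any claim that something is new, unique, unknown or untested is made for them only; others in the source may bear on it.

Measured so far in an ADME assay on HeLa cells (Homo sapiens) for cytotoxicity, read by resazurin assay, with a stated time of 2 days; a higher number here means a weaker inhibitor, a lower number a stronger inhibitor:
- compound 1 `Cn1c([N+](=O)[O-])cnc1/C=C/c1ccccc1` gives > 100000 nM
- compound 2 `Cc1ccc(/C=C/c2ncc([N+](=O)[O-])n2C)cc1` gives > 100000 nM
- compound 3 `Cn1c([N+](=O)[O-])cnc1/C=C/c1ccccc1Cl` gives > 100000 nM

All three entries are limits, not numbers. Compound 1 therefore has no exact position, only its limit of > 100000 nM. The same holds across the set, as shown by the limit of > 100000 nM in this assay, at which 3 of the 3 values shown sit.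

The unmeasured compound 4 `Cn1c([N+](=O)[O-])cnc1/C=C/c1cccc(Cl)c1` differs from compound 1 by chloro in place of hydrogen on an aromatic carbon, meta to a large group (chloro in place of hydrogen on an aromatic carbon).

The measured step with the same replacement is a step that the two limits leave unreadable from compound 1 to compound 3. The methyl replacement is a step that the two limits leave unreadable from compound 1 to compound 2. Neither step has a readable size, so neither offers a measured size or direction to carry over. No readable step is expected in this assay, and the most likely report is the same limit again. The estimated change is a number no higher from compound 1 to compound 4 (the limit leaves the size open). For compound 4 the expected value is 100000 nM, with an estimated range from 50000 nM to 200000 nM.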

Compound 4, half-maximal inhibitory concentration: 30200 nM
The estimate for compound 4 lay 3.3-fold (0.52 log units) above the measured number; the whole stated range lies above it.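

In this assay, within the data shown here, chloro in place of hydrogen on an aromatic carbon, meta to a large group, gives the first readable step: an at least 3.3-fold lower number from compound 1 to compound 4 (0.51 log units; beyond the scatter). Compound 1 gives > 100000 nM, which is a limit, so this step has a readable direction but no upper bound on its size. Compound 3 carries chloro at another place on the same ring and gives > 100000 nM, also a limit, so among the compounds shown a measurable value appears only with chloro at this place; the earlier steps from compound 1 cannot be read.

From the compounds shown here alone, whether an amine, a methoxy group or a carboxylic acid at this same place also gives a measurable value remains open. The set still offers few numbers for comparison: the limit of > 100000 nM in this assay, at which 3 of the 4 values shown sit.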